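Hydrazone aryl swaps on the shared core

A few compounds are considered here, and "the series" means these few. Any claim that something is new, unique, unknown or untested is made for them only; others in the source may bear on it.

Values in a functional assay on PC-3 cells (Homo sapiens) for antiproliferative activity, read by MTT assay; on this read-out lower numbers stand for stronger inhibition and higher numbers for weaker inhibition:
compound 1 `Cn1c(=O)c(=O)n(C2CCCC2)c2nc(N/N=C/c3cccc(Cl)c3Cl)ncc21`: 17200 nM
compound 2 `COc1ccc(/C=N/Nc2ncc3c(n2)n(C2CCCC2)c(=O)c(=O)n3C)c(OC)c1`: > 100000 nM, a limit of the assay and not a number

Compound 2 thus stands only at a limit in this assay, and the step of an at least 5.8-fold higher number from compound 1 to compound 2 (0.76 log units; beyond the scatter) rests on (the limit of > 100000 nM in this assay, at which 1 of the 2 values shown sits). Compound 3 `Cn1c(=O)c(=O)n(C2CCCC2)c2nc(N/N=C/c3ccc(O)c(Br)c3)ncc21` differs from compound 2 by 3-bromo-4-hydroxyphenyl in place of 2,4-dimethoxyphenyl on a carbon with a double bond to nitrogen. Going by the values given here, only that one step bears on the change, and it was at least modest. A halogen-bearing ring returning, as in compound 1 at 17200 nM, suggests a lower number is expected in this assay. The expected step is an at least 3.3-fold lower number from compound 2 to compound 3 (0.52 log units; beyond the scatter). Compound 3 is expected near 30000 nM, between 8000 nM and 150000 nM.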

Compound 3, half-maximal inhibitory concentration: 11600 nM
Compound 3: middle estimate off by 2.6-fold (0.41 log units), on the high side; low and high end bracket the measured number.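

In this assay, on these data alone, a ring other than 2,3-dichlorophenyl also gives a measurable value at this place, though the step of an at least 8.6-fold lower number from compound 2 to compound 3 (0.93 log units; beyond the scatter) rests on a limit of the assay for compound 2, and its true size stays unknown: the limit of > 100000 nM in this assay, at which 1 of the 3 values shown sits. The step of a 1.5-fold lower number from compound 1 to compound 3 (0.17 log units; within the scatter) does not separate 3-bromo-4-hydroxyphenyl from 2,3-dichlorophenyl, so chlorine is not required for this level of activity.

Bromine and the hydroxyl enter together, and which of them matters stays open. Also open, as far as these compounds go, is how a phenyl ring carrying an amine or a carboxylic acid would behave here.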